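Ring-contracted acid arm on a shared core

The source may hold more compounds than are shown below. What is called first, only, known or untested is meant among the compounds shown, and "the series" means these compounds.

Compound 1 `COc1ccc(/C=C\c2cc(OC)c(OC)c(OC)c2)cc1OCc1ccc(CN2CCCC[C@H]2C(=O)O)cc1` — > 10000 nM
Compound 2 `COc1ccc(/C=C\c2cc(OC)c(OC)c(OC)c2)cc1OCc1ccc(CN2CCCC[C@@H]2C(=O)O)cc1` — > 10000 nM

In a functional assay on MC-38 cells (Mus musculus) for antiproliferative activity, read by CCK-8 assay, with a stated time of 48 h (on this read-out lower numbers stand for stronger inhibition and higher numbers for weaker inhibition), compound 1 gives > 10000 nM, which is a limit of the assay rather than a number. Differing from compound 1 only in configuration as drawn, compound 2 gives > 10000 nM, likewise a limit. The step that the two limits leave unreadable from compound 1 to compound 2 thus cannot be read, because the limit of > 10000 nM in this assay, at which 2 of the 2 values shown sit, and the fact that compounds 1 and 2 differ only in the configuration as drawn leave its size open.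

Compound 3 `COc1ccc(/C=C\c2cc(OC)c(OC)c(OC)c2)cc1OCc1ccc(CN2CC(C(=O)O)C2)cc1` differs from compound 1 by 3-carboxyazetidin-1-yl in place of 2-carboxypiperidin-1-yl on a saturated chain carbon bound to an aromatic carbon. Among the compounds with values here, no measured step bears on this change, and both values known so far are limits, so no direction or size beyond the scatter can be drawn. Compound 3 is therefore expected to stay at the limit, with a step that the limit leaves unreadable from compound 1 to compound 3 estimated as no readable step. The estimate for compound 3 is 15000 nM, between 5000 nM and 50000 nM.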

Compound 3, half-maximal inhibitory concentration: > 10000 nM
Compound 3 ended at the assay's limit; the forecaster's own chance of this, stated with the estimate: 75%; the middle value does not contradict the limit.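

In this assay compound 3 also sits at a limit, so no step from compound 1 or compound 2 to compound 3 can be read: the limit of > 10000 nM in this assay, at which 3 of the 3 values shown sit.

The compounds shown leave open how far the 2-carboxypiperidin-1-yl and 3-carboxyazetidin-1-yl arms, or the configuration, affect the result.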